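A few compounds are considered here, and "the series" means these few. Any claim that something is new, unique, unknown or untested is made for them only; others in the source may bear on it.

Compound 1 `Cc1c(N(C)C)nc(CCCCCCCCCCO)c(O)c1C` — 87%
Compound 2 `CCCCCCCCCCCCCCCCCCCc1c(C)c(N(C)C)nc(C)c1O` — 87%

In a functional assay on cells (Lymphocyte, Homo sapiens), read by trypan blue exclusion, with a stated time of 16 h, tested at 2.5 uM (on this read-out lower numbers stand for a weaker effect and higher numbers for a stronger effect at the one concentration tested), compound 1 gives 87%. Compound 2, which carries a long chain on its core and no hydroxy at the chain end, gives 87% in this assay, so compound 1 stands level with compound 2 at the digits shown, the two values lying within the scatter of each other. Compound 3 `CCCCCCCCCCCCCCCCc1nc(N(C)C)c(C)c(C)c1O` has not yet been measured. It differs from compound 1 by hexyl in place of hydroxy on a saturated chain carbon, ten or more bonds along the chain from an aromatic carbon. Compound 3 thus carries a chain without a hydroxy at its end, as compound 2 does, and compound 2 gives 87% in this assay. The step of a number 2 percentage points lower from compound 1 to compound 3 (within the scatter) is therefore expected to be none beyond the scatter. Compound 3 is expected to give about 85% in this assay, within a range from 70% to 95%.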

Compound 3, a percentage reported as activity, at one concentration (the size of the read-out at that concentration, not a potency): 92%
Compound 3: middle estimate off by 7 percentage points, on the low side; the range from low to high includes it.
By their numbers in this assay, from the lowest: compounds 1, 2 and 3 (each within the scatter of the next).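

Among these compounds, the compounds measured earlier offered no pair differing in one place, so this is the only direct reading of the change at this position. In this assay, hexyl in place of hydroxy on a saturated chain carbon, ten or more bonds along the chain from an aromatic carbon, gives a number 5 percentage points higher from compound 1 to compound 3 (within the scatter) and so no difference beyond the scatter. At this single concentration, then, the read-out does not depend on the hydroxy at this place, and the position accepts a hexyl in its stead; no measurement shown here explains this result.

Going by these compounds, whether an amine or a carboxylic acid at the chain end would also leave this assay at this level remains open, as does the effect of a much shorter chain. A reading at one concentration also leaves open whether compound 1 and compound 3 match in potency.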